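The source may hold more compounds than are shown below. What is called first, only, known or untested is meant among the compounds shown, and "the series" means these compounds.

Compound 1 (`CCOC(=O)CN(C(=O)/C(C)=C/c1ccc(C(=O)Oc2ccc(C(=N)N)cc2)cc1)C1CCCC1`) is the starting point in an in vitro ADME assay on the whole organism (small intestine) for pharmacokinetics, with Rattus norvegicus as the target; on this read-out lower numbers stand for a shorter-lived compound and higher numbers for a longer-lived compound. From the compounds shown here alone, compound 1 gives > 1 h, which is a limit and not a number, so its true position is unknown; this is the limit of > 1 h in this assay, at which 1 of the 3 values shown sits. Compound 2 (`C/C(=C\c1ccc(C(=O)Oc2ccc(C(=N)N)cc2)cc1)C(=O)N(CC(=O)O)C1CCCC1`) gives 0.7 h and compound 3 (`C=CCN(CCCC(=O)OCC)C(=O)/C(C)=C/c1ccc(C(=O)Oc2ccc(C(=N)N)cc2)cc1`) gives 1 h, two values within the usual scatter of each other.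

Compound 4 (`CCOC(=O)CN(C(=O)/C(C)=C/c1ccc(C(=O)Oc2ccc(C(=N)N)cc2)cc1)C1CCCCC1`) differs from compound 1 in one place: cyclohexyl in place of cyclopentyl on an amide-type nitrogen, with cyclohexyl in place of cyclopentyl on an amide-type nitrogen. Among the measured compounds shown here, only one step has been measured from compound 1, an at least 1.4-fold lower number from compound 1 to compound 2 (0.15 log units; that floor lies within the scatter), and even its floor lies within the scatter. That step also changes another part of the molecule, so it offers no direct guide to a change on the amide-type nitrogen. For the measured compounds named here, no measured step covers this ring change, so no shift beyond the scatter in this assay is expected. The expected change is a step that the limit leaves unreadable from compound 1 to compound 4. Compound 4 is estimated at 1.3 h, with an expected range of 0.6 h to 2.8 h.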

Compound 4, half-life: > 1 h
Compound 4: only a limit was reported; the forecaster's own chance of this, stated with the estimate: 45%; the middle value lies beyond the limit too.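

Among the compounds shown here, compound 1 and compound 4 each carry only a limit in this assay, so no step between them can be read: the limit of > 1 h in this assay, at which 2 of the 4 values shown sit. From the compounds shown here alone, whether cyclohexyl in place of cyclopentyl on the amide-type nitrogen shifts the half-life at all, and in which direction, stays open.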